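From 4-bromobenzyl to 2-methylbenzyl: compound 3 to compound 4

A few compounds are considered here, and "the series" means these few. Any claim that something is new, unique, unknown or untested is made for them only; others in the source may bear on it.

In a functional assay on HUVEC cells (Homo sapiens) for antiproliferative activity, read by MTT assay, with a stated time of 24 h (on this read-out lower numbers stand for stronger inhibition and higher numbers for weaker inhibition), compound 1 (`COc1cc(OC)c(-c2coc3cc(OCc4ccccc4F)ccc3c2=O)cc1OC`) gives 4300 nM. Compound 2 (`COc1cc(OC)c(-c2coc3cc(OCc4ccc(F)cc4)ccc3c2=O)cc1OC`) reads > 10000 nM, which is a limit and not a number. Compound 3 (`COc1cc(OC)c(-c2coc3cc(OCc4ccc(Br)cc4)ccc3c2=O)cc1OC`) reads > 10000 nM, also a limit. Compound 3 therefore has no measured number and sits with compound 2 at the same limit.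

Compound 4 (`COc1cc(OC)c(-c2coc3cc(OCc4ccccc4C)ccc3c2=O)cc1OC`) differs from compound 3 as follows: 2-methylphenyl in place of 4-bromophenyl on a saturated chain carbon bound to an oxygen on an aromatic ring. In words, 2-methylphenyl stands in place of 4-bromophenyl on a saturated chain carbon bound to an oxygen on an aromatic ring.

Going by the values given here, two measured steps bear on this change. With 4-fluorophenyl in place of 2-fluorophenyl, the series shows an at least 2.3-fold higher number from compound 1 to compound 2 (0.36 log units; beyond the scatter). With 4-bromophenyl in place of 2-fluorophenyl, it shows an at least 2.3-fold higher number from compound 1 to compound 3 (0.36 log units; beyond the scatter). Bromo in place of fluoro gives a step that the two limits leave unreadable from compound 2 to compound 3, so that step offers no guidance. Among these three compounds, only the 2-substituted compound 1 gives a number, and none goes against this, though the pattern rests on a single value.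

A lower number of at least modest size is therefore expected, read as an at least 2.0-fold lower number from compound 3 to compound 4 (0.30 log units; that floor lies within the scatter). For compound 4 the expected value is 5000 nM, with an estimated range of 2000 nM to 10000 nM.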

Compound 4, half-maximal inhibitory concentration: 4830 nM
The estimate for compound 4 lay 1.0-fold (0.02 log units) above the measured number; low and high end bracket the measured number.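

In this assay, 2-methylphenyl gives the series a second measured number, with an at least 2.0-fold lower number from compound 3 to compound 4 (0.31 log units; beyond the scatter) and an at least 2.0-fold lower number from compound 2 to compound 4 (0.31 log units; beyond the scatter), so the earlier contrast no longer rests on compound 1 alone. Methyl in place of fluoro gives a 1.1-fold higher number from compound 1 to compound 4 (0.05 log units; within the scatter), which lies within the scatter, so the 2-fluorophenyl and 2-methylphenyl compounds cannot be told apart on this read-out. Both read apart from the 4-fluorophenyl and 4-bromophenyl compounds, and none of the four compounds goes against this, yet the values for compound 2 and compound 3 are limits and not numbers: the limit of > 10000 nM in this assay, at which 2 of the 4 values shown sit.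

As far as these compounds go, how far compound 2 and compound 3 truly lie from the other two stays open, and the step between those two cannot be read. Also open, from the compounds shown here alone, is how a 4-methylphenyl would read on the saturated chain carbon bound to an oxygen on an aromatic ring, which would test the place of the methyl on its own, and whether an amine, a carboxylic acid or a longer chain at that place would keep a measurable number.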